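Swapping the anilino aryl group in a cAMP agonist series

The source may report more compounds than this note shows. Statements on the series, on what has been measured and on what is new or still open speak of the compounds shown alone.

Compound 1, `CC1(OC(=O)N2C[C@H]3COC[C@@H](C2)[C@@H]3Oc2ncnc(Nc3ccccc3F)c2F)CC1`: 25 nM
Compound 2, `CC1(OC(=O)N2CC3COCC(C2)C3Oc2ncnc(Nc3ccc(C#N)cc3Cl)c2F)CCC1`: 60 nM
Compound 3, `CC1(OC(=O)N2CC3COCC(C2)C3Oc2ncnc(Nc3ccc(F)cc3F)c2F)CC1`: 44 nM

These three compounds share a common core and were all tested in a functional assay for agonist activity at Glucose-dependent insulinotropic receptor (Mus musculus), read by cAMP accumulation; a lower number here means that less compound is needed, a higher number that more compound is needed for the effect. Compound 1 gives the lowest number of the three with 25 nM. Compound 3 comes nearest with 44 nM, a gap that lies within the scatter of the assay, so no order between compound 1 and compound 3 can be read from these two values. Compound 2 stands furthest off with 60 nM, a gap that lies beyond the scatter.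

Compound 4, `CC1(OC(=O)N2C[C@H]3COC[C@@H](C2)[C@@H]3Oc2ncnc(Nc3ccc(C#N)cc3Cl)c2F)CC1`, has not yet been measured. It differs from compound 1 in a single place: 2-chloro-4-cyanophenyl in place of 2-fluorophenyl on a nitrogen on an aromatic ring. Compound 2 carries this same 2-chloro-4-cyanophenyl group on its core without defined stereochemistry and gives 60 nM in this assay. Within the data shown here, since no step between measured compounds covers this exact change, the expectation rests on that value: a modest rise in the number, of about a 2.0-fold higher number from compound 1 to compound 4 (0.30 log units; within the scatter), is expected. For compound 4 the estimate in this assay is 50 nM, with a range from 20 nM to 130 nM.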

Compound 4, half-maximal effective concentration: 58 nM
Compound 4: the middle estimate sits 1.2-fold (0.06 log units) below what was measured; the range from low to high includes it.
By their numbers in this assay, from the lowest: compounds 1, 3, 4 and 2 (each within the scatter of the next, the first and the last beyond it).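

Among these compounds, the step from compound 1 to compound 4 is the first in this set that isolates a change in one place: in this assay, 2-chloro-4-cyanophenyl in place of 2-fluorophenyl on a nitrogen on an aromatic ring gives a 2.3-fold higher number from compound 1 to compound 4 (0.37 log units; beyond the scatter). The step is modest, so this position accepts the larger group, which adds a nitrile, with agonist activity retained at a higher number. No measurement here explains the rise.

The change brings in the chlorine and the nitrile together, so the compounds shown do not separate their contributions; a 2-chlorophenyl group and a 4-cyano-2-fluorophenyl group on the same nitrogen would do so. As far as these compounds go, it also remains open whether a carboxylic acid or an amine at this aryl group would fit the same trend.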